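The source may report more compounds than this note shows. Statements on the series, on what has been measured and on what is new or still open speak of the compounds shown alone.

Measured in a functional assay on HL-60 cells (Homo sapiens) for antiproliferative activity, with a stated time of 24 h; on this read-out lower numbers stand for stronger inhibition and higher numbers for weaker inhibition:
compound 1 `NC(=O)c1c(NC(=O)c2ccccc2Cl)sc2c1CCN(Cc1ccc(Cl)cc1Cl)C2`: 8010 nM
compound 2 `NC(=O)c1c(NC(=O)c2ccccc2Cl)sc2c1CCN(C(=S)Nc1ccccc1)C2`: 5940 nM
compound 3 `Cc1ccccc1NC(=S)N1CCc2c(sc(NC(=O)c3ccccc3Cl)c2C(N)=O)C1`: 22600 nM

Compound 3 gives the highest number of the three; the steps of a 2.8-fold higher number from compound 1 to compound 3 (0.45 log units; beyond the scatter) and a 3.8-fold higher number from compound 2 to compound 3 (0.58 log units; beyond the scatter) both lie beyond the scatter, so compound 3 is the weakest of the set. Compound 4 `NC(=O)c1c(NC(=O)c2ccccc2Cl)sc2c1CCN(C(=S)Nc1cccnc1)C2` differs from compound 3 by pyridin-3-yl in place of 2-methylphenyl on an amide-type nitrogen. The step that bears most on this change is a 3.8-fold higher number from compound 2 to compound 3 (0.58 log units; beyond the scatter), which compound 4 undoes in removing the methyl; the step of a 1.3-fold lower number from compound 1 to compound 2 (0.13 log units; within the scatter) shows that exchanging the whole group on the ring nitrogen stayed within the scatter. Among the compounds with values here, no measured step covers a nitrogen inside the aromatic ring. A modest fall in number is therefore expected, a 3.2-fold lower number from compound 3 to compound 4 (0.51 log units; beyond the scatter), back toward the level of compound 2. For compound 4 the expected value in this assay is 7000 nM, with a range of 2500 nM to 20000 nM.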

Compound 4, half-maximal inhibitory concentration: 33900 nM
Beside the measured number, compound 4's estimate is 4.8-fold (0.69 log units) below it; the measured number lies above the stated range.
By their numbers in this assay, from the lowest: compounds 2 and 1 (each within the scatter of the next); then compounds 3 and 4 (each within the scatter of the next).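

In this assay, pyridin-3-yl on the amide-type nitrogen does not return the number to the phenyl level: a 5.7-fold higher number from compound 2 to compound 4 (0.76 log units; beyond the scatter) stands beyond the scatter. Against 2-methylphenyl, a 1.5-fold higher number from compound 3 to compound 4 (0.18 log units; within the scatter) stays within the scatter, so both replacements of phenyl read alike here. The exchange on the ring amine nitrogen, within the scatter for compound 2, is no longer neutral with pyridin-3-yl, as a 4.2-fold higher number from compound 1 to compound 4 (0.63 log units; beyond the scatter) shows.

No evidence accounts for the weaker result of compound 4. Open, on these data alone, is whether pyridin-4-yl or 4-methylphenyl on this nitrogen would stay near compound 2 or join compound 3 and compound 4.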